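Following compound 2 to compound 4

The compounds below may be only part of what the source reports. "The series", "measured", "known", "first", "only" and "open" are said of these compounds alone.

Measured so far in a functional assay on cells (CNS carcinoma cell, Homo sapiens) for cytotoxicity, read by sulforhodamine B assay, with a stated time of 48 h; on this read-out lower numbers stand for stronger inhibition of growth and higher numbers for weaker inhibition of growth
- compound 1 `COc1ccc2c(c1)/C(=C/c1c(-c3ccncc3)nc3sccn13)C(=O)N2C` at 380 nM
- compound 2 `COc1cc2c(cc1C)NC(=O)/C2=C/c1c(OC)nc2sc(C)cn12` at 5700 nM
- compound 3 `COc1nc2sc(C)cn2c1C=C1C(=O)N(C)c2ccccc21` at 9820 nM

Compound 2 at 5700 nM lies within the scatter of compound 3 at 9820 nM. Compound 1 at 380 nM has the lower number on this read-out, and its gap to compound 2 is larger than the scatter. Compound 4 `COc1ccc2c(c1)/C(=C\c1c(OC)nc3sc(C)cn13)C(=O)N2` departs from compound 2 by hydrogen in place of methyl on an aromatic carbon and nothing else. For the measured compounds named here, no measured pair isolates this change, so the size of the step is not known from the data. In this assay no step beyond the scatter is expected, in either direction. The expected 1.1-fold lower number from compound 2 to compound 4 (0.06 log units; within the scatter) is small and rests on compound 2 at 5700 nM as the anchor. Compound 4 is estimated at 5000 nM and 1800 nM to 14000 nM is its expected range.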

Compound 4, concentration for 50% growth inhibition: 430 nM
Beside the measured number, compound 4's estimate is 12-fold (1.07 log units) above it; measured number below the stated range.
By their numbers in this assay, from the lowest: compounds 1 and 4 (each within the scatter of the next); then compounds 2 and 3 (each within the scatter of the next).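

In this assay, the aromatic carbon ortho to a methoxy group proves sensitive to substitution: hydrogen in place of methyl gives a 13-fold lower number from compound 2 to compound 4 (1.12 log units; beyond the scatter). For the compounds shown here, the earlier compounds offered no matched pair at this position, so this is the first measured size for the change, and it is large. Nothing shown accounts for the step.

Still open, as far as these compounds go, is how a fluorine, a chlorine, an ethyl chain or an amine on this carbon would compare with hydrogen and methyl. From the compounds shown here alone, whether the step carries over to other members also remains open.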